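A few compounds are considered here, and "the series" means these few. Any claim that something is new, unique, unknown or untested is made for them only; others in the source may bear on it.

For the measured compounds named here, in an assay on HEK293 cells for inhibition of Voltage-dependent N-type calcium channel subunit alpha-1B (Homo sapiens), read by patch clamp, using a membrane potential dye (on this read-out lower numbers stand for stronger inhibition and higher numbers for weaker inhibition), compound 1 `COc1ccccc1-n1nc(C2CC(C)(C)OC(C)(C)C2)cc1-c1ccc(Cl)cc1` gives 24 nM, the lowest of the two numbers so far. Compound 3 `CCOc1ccc(-c2cc(C3CC(C)(C)OC(C)(C)C3)nn2-c2ccccc2OC)cc1` gives 61 nM, and the step of a 2.5-fold higher number from compound 1 to compound 3 (0.41 log units; beyond the scatter) is the only measured one. For compound 2 `COc1ccccc1-n1nc([C@@H]2CCO[C@@H](C(C)C)C2)cc1-c1ccc(Cl)cc1` the entry in this assay is "not determined" (no result reported), so no number is available for it. Compound 4 `COc1ccccc1-n1nc(C2CCOC(C)(C)C2)cc1-c1ccc(Cl)cc1` differs from compound 1 in one place: 2,2-dimethyloxan-4-yl in place of 2,2,6,6-tetramethyloxan-4-yl on an aromatic carbon. Going by the values given here, no measured step touches this ring; the single step known concerns the aryl group on the other side of the core, so nothing directly bears on the change. The expectation for compound 4 therefore rests on compound 1 alone, with no step beyond the scatter in either direction, giving an estimated step of a 1.7-fold higher number from compound 1 to compound 4 (0.22 log units; within the scatter) and an expected value of 40 nM, between 12 nM and 130 nM.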

Compound 4, half-maximal inhibitory concentration: 150 nM
Beside the measured number, compound 4's estimate is 3.8-fold (0.57 log units) below it, outside the stated range (above it).
By their numbers in this assay, from the lowest: compound 1; then compound 3; then compound 4.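

In this assay, for the compounds shown here, 2,2-dimethyloxan-4-yl in place of 2,2,6,6-tetramethyloxan-4-yl gives a 6.3-fold higher number from compound 1 to compound 4 (0.80 log units; beyond the scatter) and so shows for the first time that the group on this aromatic carbon of the five-membered ring affects the reading. The full set of four methyl groups in compound 1 goes with the lowest number of the three compounds with values. No available evidence accounts for this step.

What the compounds shown leave open is how the plain oxan-4-yl ring or a piperidine amine would read at this place. Also open, on these data alone, is whether the ethoxy step holds on the 2,2-dimethyloxan-4-yl compound.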